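A Hydroxyphenyl Hydrazone Step Tested Against Lung Cancer Cells

The source may report more compounds than this note shows. Statements on the series, on what has been measured and on what is new or still open speak of the compounds shown alone.

Compound 1 `CN(C)CCn1cnnc1-c1cc(Oc2ccc(NC(=O)N/N=C/c3ccc(O)c(Br)c3)cc2F)ccn1` gives 1370 nM in a functional assay on A549 cells (Homo sapiens) for cytotoxicity, read by MTT assay, with a stated time of 72 h; on this read-out lower numbers stand for stronger inhibition and higher numbers for weaker inhibition. Compound 2 `CN(C)CCn1cnnc1-c1cc(Oc2ccc(NC(=O)N/N=C/c3ccccc3)cc2F)ccn1` gives 1860 nM in this assay. Compound 3 `CN(C)CCn1cnnc1-c1cc(Oc2ccc(NC(=O)N/N=C/c3ccc(O)c(O)c3)cc2F)ccn1` reaches only the limit of > 100000 nM in this assay.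

Among the two numbers shown, compound 1 sits lowest, with compound 2 nearest: a 1.4-fold higher number from compound 1 to compound 2 (0.13 log units; within the scatter). Compound 3 gives no number, only a limit, as the limit of > 100000 nM in this assay, at which 1 of the 3 values shown sits, shows. Compound 4 `CN(C)CCn1cnnc1-c1cc(Oc2ccc(NC(=O)N/N=C/c3cccc(O)c3)cc2F)ccn1` is the untested member of this set. It differs from compound 1 in one place: 3-hydroxyphenyl in place of 3-bromo-4-hydroxyphenyl on a carbon with a double bond to nitrogen.

Within the data shown here, three measured steps bear on this change. Dropping the whole 3-bromo-4-hydroxyphenyl for plain phenyl barely moved the number, a 1.4-fold higher number from compound 1 to compound 2 (0.13 log units; within the scatter). Turning the bromo into a second hydroxy, however, was drastic, an at least 72-fold higher number from compound 1 to compound 3 (1.86 log units; beyond the scatter), and an at least 53-fold higher number from compound 2 to compound 3 (1.73 log units; beyond the scatter) tells the same story from the phenyl side. A single hydroxy in the 3-hydroxyphenyl group lies between those two situations, so a modest weakening is expected rather than a collapse, a 2.0-fold higher number from compound 1 to compound 4 (0.31 log units; beyond the scatter). Compound 4 is therefore estimated at 2800 nM, within 900 nM to 15000 nM.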

Compound 4, half-maximal inhibitory concentration: > 100000 nM
Compound 4: a limit, no number (the forecaster's own chance of this, stated with the estimate: 15%); middle value at least 35-fold (1.55 log units) from the limit.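

Compound 4 gives only a limit and no number, as compound 3 does: the limit of > 100000 nM in this assay, at which 2 of the 4 values shown sit. So on this carbon with a double bond to nitrogen, a lone hydroxy on the phenyl ring is enough to lose the measurable effect of plain phenyl, an at least 53-fold higher number from compound 2 to compound 4 (1.73 log units; beyond the scatter), and the swap away from 3-bromo-4-hydroxyphenyl is just as costly, an at least 72-fold higher number from compound 1 to compound 4 (1.86 log units; beyond the scatter). Compound 1 goes against any simple rule that a hydroxy spoils activity, as it carries one together with a bromo, while the step between the two limit compounds, compound 3 and compound 4, cannot be read.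

From the compounds shown here alone, what remains open is whether a 3-bromophenyl group, with bromo and no hydroxy, would give a number like that of compound 1. Also open, going by these compounds, is whether a methoxy or an amine in place of the hydroxy of compound 4 would bring a number back.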